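Bromo for chloro: the step from compound 2 to compound 3

A few compounds are considered here, and "the series" means these few. Any claim that something is new, unique, unknown or untested is made for them only; others in the source may bear on it.

For the measured compounds named here, compound 2 `O=C(Nc1ccc(Cl)cc1)Nn1c(-c2ccccc2)nc2ccccc2c1=O` stands lowest of the two numbers measured so far in a functional assay on the whole organism (strain albino) with Mus musculus as the target, at a dose of 100 mg/kg by the intraperitoneal route (on this read-out higher numbers stand for more inhibition at the one dose given (going by the name of the read-out) and lower numbers for less inhibition), giving 55%; compound 1 `O=C(Nc1ccccc1)Nn1c(-c2ccccc2)nc2ccccc2c1=O` gives 56%, and the step of a number 1 percentage points lower from compound 1 to compound 2 (within the scatter) lies within the scatter, so the two compounds cannot be ordered. Compound 3 `O=C(Nc1ccc(Br)cc1)Nn1c(-c2ccccc2)nc2ccccc2c1=O` differs from compound 2 by bromo in place of chloro on an aromatic carbon. Going by the values given here, no measured step exchanges one halogen for another, so nothing bears on this change directly. Among the compounds with values here, the single step in hand, chloro in place of hydrogen on an aromatic carbon, left the read-out essentially unchanged within the scatter. On that basis no movement beyond the scatter is expected in this assay from compound 2 to compound 3, and the estimated step is no change at the digits printed from compound 2 to compound 3 (within the scatter). Compound 3 is therefore estimated at 55% in this assay, with a range from 42% to 68%.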

Compound 3, a percentage reported as inhibition, in the whole organism at one dose (the size of the read-out at that dose, not a potency): 58%
For compound 3 the middle estimate is 3 percentage points below the measured one, and the stated range covers the measured number.
By their numbers in this assay, from the lowest: compounds 2, 1 and 3 (each within the scatter of the next).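

In this assay, the exchange of halogen on this aromatic carbon, para to a large group, gives a number 3 percentage points higher from compound 2 to compound 3 (within the scatter), so bromo and chloro cannot be told apart at this position. Against the compound with hydrogen at the same carbon, the series shows a number 2 percentage points higher from compound 1 to compound 3 (within the scatter), making bromo the second halogen here whose value stays within the scatter of the unsubstituted 4-position phenyl. Nothing at hand offers an explanation for how little the read-out responds to these exchanges.

From the compounds shown here alone, whether an amine, a carboxylic acid or a methoxy group on this carbon would move the read-out beyond the scatter remains open. Also open, going by these compounds, is whether a change elsewhere on the shared core, such as a longer chain in place of the phenyl group, would shift the number at this dose.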